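This account rests on a few compounds, and the source may have more. Where it says the series, first, only, none or still open, it means among the compounds named here.

Compound 1 `c1ccc(COc2cccc(OCCCc3nnn[nH]3)c2)nc1` stands lowest of the two measured compounds in an assay on isolated protein for binding affinity to cysteinyl leukotriene receptor 1 (Cavia porcellus), tested at 10 uM; a higher number here means more inhibition at the concentration tested (going by the name of the read-out), a lower number less inhibition: compound 1 gives 10%, while its nearest neighbour, compound 2 `c1ccc(-c2ccc(COc3cccc(OCCCc4nnn[nH]4)c3)nc2)cc1`, gives 58%. For the measured compounds named here, the single measured step, a number 48 percentage points higher from compound 1 to compound 2 (beyond the scatter), is large and beyond the scatter. Compound 3 `c1ccc(Oc2cccc(COc3cccc(OCCCc4nnn[nH]4)c3)n2)cc1` differs from compound 1 in one place: phenoxy in place of hydrogen on an aromatic carbon. The step from compound 1 to compound 2 is the only one that bears on this change, since both add a six-membered aromatic ring of carbon only to the shared core, though in compound 3 the ring enters as a phenoxy group, carried through an oxygen. A rise beyond the scatter is therefore expected, although a smaller gain than that seen with compound 2 remains possible, so the expected step is a number 30 percentage points higher from compound 1 to compound 3 (beyond the scatter). Compound 3 is estimated at 40% in this assay, with a range from 15% to 70%.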

Compound 3, a percentage reported as inhibition, at one concentration (the size of the read-out at that concentration, not a potency): 48%
Compound 3: middle estimate off by 8 percentage points, on the low side; the range from low to high includes it.
By their numbers in this assay, from the lowest: compound 1; then compounds 3 and 2 (each within the scatter of the next).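

In this assay, phenoxy in place of hydrogen on an aromatic carbon, next to the ring nitrogen, brings a number 38 percentage points higher from compound 1 to compound 3 (beyond the scatter) in a large step. Until now, the only gain on this ring came from phenyl, so this result shows that a second gain is possible with a six-membered aromatic ring of carbon only that is carried through an oxygen and stands on an aromatic carbon next to the ring nitrogen. No measurement offered here accounts for the rise.

The compounds shown leave open whether the aromatic ring is needed at this place, or whether a methoxy group or an amine there would also raise the number. They also leave open whether the oxygen matters, which an anilino or benzyl group at the same place could test.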